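Methyl in Place of Fluoro: From Compound 1 to Compound 3

The compounds below may be only part of what the source reports. "The series", "measured", "known", "first", "only" and "open" are said of these compounds alone.

For the measured compounds named here, compound 1 `O=S(=O)(Nc1ccc2oc(-c3ccccc3)nc2c1)c1cccc(F)c1` is the only compound in this set that gives an actual number in an ADME assay on HEK293 cells (Homo sapiens) for cytotoxicity, read by resazurin assay, with a stated time of 48 h; a lower number here means that less compound is tolerated, a higher number that more compound is tolerated; in that assay compound 1 gives 68000 nM. Compound 2 `O=S(=O)(Nc1ccc(-c2nc3ccccc3o2)cc1)c1cccc(Cl)c1` was also tested in this assay, where compound 2 gives > 100000 nM, which is a limit of the assay and not a number. Going by the values given here, the one other value shown is thus (the limit of > 100000 nM in this assay, at which 1 of the 2 values shown sits). Among the compounds with values here, with a single number and a single limit, no step between measured compounds can be drawn, so compound 1 stands alone as the only fixed point.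

Compound 3 `Cc1cccc(S(=O)(=O)Nc2ccc3oc(-c4ccccc4)nc3c2)c1` differs from compound 1 in one place: methyl in place of fluoro on an aromatic carbon. The change is a small one, a single heavy atom exchanged for another on the same aromatic carbon, with no ring, no donor and no acceptor gained or lost.

With nothing measured to anchor the size of such an exchange, no step beyond the usual scatter is expected in this assay; the step of a 1.0-fold higher number from compound 1 to compound 3 (0.01 log units; within the scatter) is estimated to stay within that scatter, in no particular direction. In this assay compound 3 is therefore expected to give about 70000 nM, with a likely range from 35000 nM to 140000 nM.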

Compound 3, half-maximal cytotoxic concentration: 69000 nM
Compound 3: the middle estimate sits 1.0-fold (0.01 log units) above what was measured; low and high end bracket the measured number.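

In this assay, for the compounds shown here, the exchange of fluoro for methyl gives the only step in this set that can be read, a 1.0-fold higher number from compound 1 to compound 3 (0.01 log units; within the scatter), and that step lies within the scatter. On the shared core, at this place on the six-membered aromatic ring of carbon only, 3-fluorophenyl and 3-methylphenyl therefore cannot be told apart in this read-out, and compound 1 is no longer the lone fixed point. Going by these compounds alone, compound 1 and compound 3 both give actual numbers, whereas the remaining value in the set is a limit of the assay and fixes no step: the limit of > 100000 nM in this assay, at which 1 of the 3 values shown sits.

The compounds shown leave open whether any other group at this place, such as an amine, a carboxylic acid, a nitrile or a longer chain, would give a step beyond the scatter, as a single exchange between two small groups cannot show how much room this position has. They also leave open whether the exchange of fluoro for methyl would read the same at another place on this ring or on a different core.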